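Swapping the Amide Aryl Group in a Non-Toxic Series

The source may report more compounds than this note shows. Statements on the series, on what has been measured and on what is new or still open speak of the compounds shown alone.

Compound 1, `COc1ccc(-c2cnc(NC(=O)c3ncc[nH]3)n2C)cc1`: in a toxicity assay on THP-1 cells (Homo sapiens) for inhibition (on this read-out higher numbers stand for lower toxicity in this test and lower numbers for higher toxicity in this test), compound 1 gives > 100000 nM, a limit of the assay.
Compound 2, `COc1ccc(-c2cn(C)c(NC(=O)c3ccc(F)cc3)n2)cc1`: in this assay compound 2 gives > 50000 nM, also a limit.
Compound 3, `Cn1c(-c2ccccc2F)cnc1NC(=O)c1ccc(F)cc1`: in this assay compound 3 gives > 100000 nM, again a limit.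

Compound 1 thus stands at the upper limit of this assay rather than at a number, and it shares that position with compound 3, while compound 2 sits at a lower limit. Compound 4, `COc1ccc(-c2cnc(NC(=O)c3cccc(C#N)c3)n2C)cc1`, differs from compound 1 by 3-cyanophenyl in place of 1H-imidazol-2-yl on a carbonyl carbon. Among the measured compounds shown here, no measured pair shows such a change, so the expectation rests on the fact that every compound shown sits at a limit of > 100000 nM in this assay, at which 2 of the 3 values shown sit (the limit of > 50000 nM in this assay, at which 1 of the 3 values shown sits). Compound 4 is expected to show no step beyond the scatter, that is a number no higher from compound 1 to compound 4 (the limit leaves the size open), and its expected value is 100000 nM, within 30000 nM to 300000 nM.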

Compound 4, half-maximal cytotoxic concentration: > 100000 nM
Compound 4 gave a limit, no number; the forecaster's own chance of this, stated with the estimate: 80%; the middle value sits exactly at the limit.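

Compound 1 and compound 4 both sit at a limit in this assay, so no step can be read between them. The compounds shown leave open whether 3-cyanophenyl in place of 1H-imidazol-2-yl changes toxicity at all.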